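Compound 3 to Compound 4: A Changed Benzyl Group

The source may hold more compounds than are shown below. What is called first, only, known or untested is meant among the compounds shown, and "the series" means these compounds.

Compound 1 `COc1ccc2cc([C@H](C)c3nnc(SCc4ccc(F)cc4)n3-c3ccc(Cl)cc3)ccc2c1` in a functional assay on LNCaP cells (Homo sapiens) for cytotoxicity, read by MTT assay (a higher number here means a weaker inhibitor, a lower number a stronger inhibitor), gives 33900 nM
Compound 2 `COc1ccc2cc([C@H](C)c3nnc(SCc4c(Cl)cccc4Cl)n3-c3cccc(Cl)c3)ccc2c1` in this assay gives 73700 nM
Compound 3 `COc1ccc2cc([C@H](C)c3nnc(SCc4ccc(C)cc4)n3-c3ccc(Cl)cc3)ccc2c1` in this assay gives 52200 nM

Compound 3 lies within the scatter of both compound 1 and compound 2. Compound 4 `COc1ccc2cc([C@H](C)c3nnc(SCc4c(Cl)cccc4Cl)n3-c3ccc(Cl)cc3)ccc2c1` departs from compound 3 by 2,6-dichlorophenyl in place of 4-methylphenyl on a saturated chain carbon bound to a sulfur. For the measured compounds named here, the only measured step, a 1.5-fold higher number from compound 1 to compound 3 (0.19 log units; within the scatter), puts methyl in place of fluoro on an aromatic carbon and does not test this change directly. Compound 2 also carries 2,6-dichlorophenyl and gives 73700 nM in this assay, so no step beyond the scatter is expected. The estimated change is a 1.1-fold higher number from compound 3 to compound 4 (0.06 log units; within the scatter) in this assay overall. For compound 4 the expected value is 60000 nM, with an estimated range from 30000 nM to 120000 nM.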

Compound 4, half-maximal inhibitory concentration: > 400000 nM
Compound 4: only a limit was reported; the forecaster's own chance of this, stated with the estimate: 10%; middle value at least 6.6-fold (0.82 log units) from the limit.
By their numbers in this assay, from the lowest: compounds 1, 3 and 2 (each within the scatter of the next, the first and the last beyond it). At a limit, above all of these: compound 4.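

Compound 4 gives only a limit in this assay: the limit of > 400000 nM in this assay, at which 1 of the 4 values shown sits. The group on the sulfur-bound chain carbon can shift this read-out beyond the scatter: 2,6-dichlorophenyl in place of 4-methylphenyl gives an at least 7.6-fold higher number from compound 3 to compound 4 (0.88 log units; beyond the scatter), and in place of 4-fluorophenyl it gives an at least 11-fold higher number from compound 1 to compound 4 (1.07 log units; beyond the scatter). With 2,6-dichlorophenyl held fixed, the group on the aromatic nitrogen also counts, since 4-chlorophenyl in place of 3-chlorophenyl gives an at least 5.4-fold higher number from compound 2 to compound 4 (0.73 log units; beyond the scatter).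

Going by these compounds, whether both chlorines are needed for this shift remains open. So does how an unsubstituted benzyl, a 2-chlorobenzyl or a longer alkyl chain on the sulfur would read.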